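Urea series, liver-cell cytotoxicity: methoxy analogue of compound 2

The source may report more compounds than this note shows. Statements on the series, on what has been measured and on what is new or still open speak of the compounds shown alone.

Measured compounds:
compound 1 `O=C(Nc1ccc(-n2ncc3c(C(F)(F)F)cccc32)cc1)Nc1ccc(Cl)c(C(F)(F)F)c1`: 8000 nM
compound 2 `CNc1cccc2c1cnn2-c1ccc(NC(=O)Nc2ccc(Cl)c(C(F)(F)F)c2)cc1`: 3000 nM

In a functional assay on HepG2 cells (Homo sapiens) for cytotoxicity, read by MTT assay, with a stated time of 72 h (on this read-out lower numbers stand for stronger inhibition and higher numbers for weaker inhibition), compound 1 gives 8000 nM and compound 2 gives 3000 nM. Among the compounds with values here, compound 2 thus shows the lowest of the two numbers, with compound 1 as its only neighbour, the step of a 2.7-fold lower number from compound 1 to compound 2 (0.43 log units; beyond the scatter) being modest. Compound 3 `COc1cccc2c1cnn2-c1ccc(NC(=O)Nc2ccc(Cl)c(C(F)(F)F)c2)cc1` is not yet measured. It differs from compound 2 by methoxy in place of methylamino on an aromatic carbon. Within the data shown here, no measured step exchanges these two groups; the step from compound 1 to compound 2 at the same place was modest, which argues for a small step here as well. A slight rise is expected, a 1.5-fold higher number from compound 2 to compound 3 (0.18 log units; within the scatter), near the scatter. For compound 3 the estimate in this assay is 4500 nM, within 2000 nM to 10000 nM.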

Compound 3, half-maximal inhibitory concentration: 4000 nM
Estimate against measurement, compound 3: 1.1-fold (0.05 log units) above; the measured number falls inside the stated range.
By their numbers in this assay, from the lowest: compounds 2, 3 and 1 (each within the scatter of the next, the first and the last beyond it).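

In this assay, methoxy in place of methylamino on this aromatic carbon gives a 1.3-fold higher number from compound 2 to compound 3 (0.12 log units; within the scatter) and so does not resolve the loss of the hydrogen-bond donor of methylamino at this position. Methoxy in place of trifluoromethyl at the same place gives a 2.0-fold lower number from compound 1 to compound 3 (0.30 log units; within the scatter) and so leaves only methylamino separated from trifluoromethyl here. No measurement bearing on the cause of these steps is available.
On these data alone, whether a primary amine or a longer ether such as ethoxy on this carbon would move the number beyond the scatter remains open.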